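Trimming a methyl from an inactive starting point

The source may hold more compounds than are shown below. What is called first, only, known or untested is meant among the compounds shown, and "the series" means these compounds.

Measured so far:
Compound 1 `CC(C)c1cnc(Nc2cccc(F)c2)nc1NCCCNC(=O)C1CCC1`: > 1000 nM
Compound 2 `CC(C)n1cc(Nc2ncc(C3CC3)c(NCCCNC(=O)C3CCC3)n2)cn1`: 4 nM

In an assay on isolated protein for inhibition of serine/threonine-protein kinase TBK1 (Homo sapiens) (a lower number here means a stronger inhibitor, a higher number a weaker inhibitor), compound 1 reports only a limit, > 1000 nM, not a number. Compound 2 gives 4 nM in this assay. Compound 1 therefore stands at the limit of > 1000 nM in this assay, at which 1 of the 2 values shown sits. Compound 3 `CCc1cnc(Nc2cccc(F)c2)nc1NCCCNC(=O)C1CCC1` differs from compound 1 by hydrogen in place of methyl on a saturated chain carbon bound to an aromatic carbon and a saturated chain carbon. Among the compounds with values here, no step between measured compounds is available, so the size of this change is expected rather than known. Compound 1 already rests at the limit, and the expected step is a step that the limit leaves unreadable from compound 1 to compound 3, likely within the scatter. Compound 3 is estimated at 3000 nM, between 1000 nM and 10000 nM.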

Compound 3, half-maximal inhibitory concentration: 63 nM
Compound 3: middle estimate off by 48-fold (1.68 log units), on the high side; the whole stated range lies above it.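

In this assay, going from isopropyl to ethyl on a saturated chain carbon bound to an aromatic carbon gives an at least 15-fold lower number from compound 1 to compound 3 (1.20 log units; beyond the scatter). The loss of a single methyl is thus enough to turn the inactive compound 1 into a measurable inhibitor, which shows how sensitive this place is to one carbon. Compound 1 gives > 1000 nM, which is a limit and not a number, so the step has no upper bound: the limit of > 1000 nM in this assay, at which 1 of the 3 values shown sits.

On these data alone, whether a methyl, a chlorine atom or a nitrile in place of the ethyl would carry the gain further stays open. Compound 2 differs from compound 3 in more than one place, so it cannot show how the ethyl itself ranks.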